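Arylpiperazine Amides in a Mouse Seizure Model

The source may report more compounds than this note shows. Statements on the series, on what has been measured and on what is new or still open speak of the compounds shown alone.

Measured compounds:
- compound 1, `COc1cccc(N2CCN(C(=O)CN3C(=O)CC(C)(c4ccccc4)C3=O)CC2)c1`: "not active" (no number reported)
- compound 2, `CC1(c2ccccc2)CC(=O)N(CC(=O)N2CCN(c3ccc(F)cc3)CC2)C1=O`: 100 mg/kg
- compound 3, `CC1(c2ccccc2)CC(=O)N(CC(=O)N2CCN(c3ncccn3)CC2)C1=O`: "not active" (no number reported)

Three compounds share a common core and differ only in the aromatic group carried on the amine nitrogen of the piperazine ring. They were tested in a functional assay on the whole organism (strain CD-1) with Mus musculus as the target, in the maximal electroshock model, with a stated time of 2 h; a lower number here means that less compound is needed, a higher number that more compound is needed for the effect. In this assay compound 2 gives 100 mg/kg. Compound 1 was reported as "not active" (no number reported), and compound 3 likewise as "not active" (no number reported), so compound 3 stands without a number of its own; it shares that status with compound 1, and no comparison of size can be made between it and compound 2.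

Compound 4, `CC1(c2ccccc2)CC(=O)N(CC(=O)N2CCN(c3cccc(C(F)(F)F)c3)CC2)C1=O`, has not yet been measured. It differs from compound 3 by 3-(trifluoromethyl)phenyl in place of pyrimidin-2-yl on an amine nitrogen in a ring. No measured pair allows a step to be calculated for this change, so the expected size cannot rest on any shown step; the only anchor is that one aryl variant, compound 2, gave a number at all, while compound 1 and compound 3 did not. On that basis compound 4 is expected to give roughly 150 mg/kg, within a range from 60 mg/kg to 300 mg/kg, with a real chance that only "not active" is reported.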

Compound 4, minimum effective dose: 300 mg/kg
For compound 4 the middle estimate is 2.0-fold (0.30 log units) below the measured one; low and high end bracket the measured number.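

In this assay, 3-(trifluoromethyl)phenyl on this amine nitrogen still gives a number, and the choice between the two substituted phenyl groups matters: the step is a 3.0-fold higher number from compound 2 to compound 4 (0.48 log units; beyond the scatter), which lies beyond the usual scatter. Compound 2 and compound 4 thus both pair a ring of carbon only with a measurable dose, although compound 1 goes against this pattern, and steps involving the compounds reported as "not active" cannot be read. Nothing available here accounts for the difference between compound 2 and compound 4.

As far as these compounds go, it remains open how an unsubstituted phenyl ring or a pyridine ring would behave at this position. Also unresolved is whether a chlorine atom on the phenyl ring would give a lower or a higher number than the groups shown.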